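Bicyclic amine replaces cyclopropylpiperidine on the piperazine nitrogen

The compounds below may be only part of what the source reports. "The series", "measured", "known", "first", "only" and "open" are said of these compounds alone.

The three measured compounds share one core and differ only in the group carried on the piperazine nitrogen. Compound 1 `CCN(CC)CCN1CCN(C(=O)COCCN(C)S(=O)(=O)c2c(C)cc(OC)cc2C)CC1` gives 10 nM in an assay on HEK293 cells for displacement of a labelled ligand from B1 bradykinin receptor (Homo sapiens), read by scintillation counting; a higher number here means a weaker inhibitor, a lower number a stronger inhibitor. Compound 2 `COc1cc(C)c(S(=O)(=O)N(C)CCOCC(=O)N2CCN(CCN(C)C)CC2)c(C)c1` gives 106 nM in this assay, and an 11-fold higher number from compound 1 to compound 2 (1.03 log units; beyond the scatter). Compound 3 `COc1cc(C)c(S(=O)(=O)N(C)CCOCC(=O)N2CCN(C3CCN(C4CC4)CC3)CC2)c(C)c1` gives 0.8 nM in this assay, the lowest of the three numbers: a 13-fold lower number from compound 1 to compound 3 (1.10 log units; beyond the scatter), and a 130-fold lower number from compound 2 to compound 3 (2.12 log units; beyond the scatter).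

Compound 4 `COc1cc(C)c(S(=O)(=O)N(C)CCOCC(=O)N2CCN([C@@H]3CN4CCC3CC4)CC2)c(C)c1` carries a group of 8 heavy atoms (7 carbon, 1 nitrogen; 2 six-membered non-aromatic rings with 1 hetero atom each) in place of a group of 9 heavy atoms (8 carbon, 1 nitrogen; one three-membered non-aromatic ring of carbon only, one six-membered non-aromatic ring with 1 hetero atom), on an amine nitrogen in a ring. The measured steps that bear on this change are a 13-fold lower number from compound 1 to compound 3 (1.10 log units; beyond the scatter) and a 130-fold lower number from compound 2 to compound 3 (2.12 log units; beyond the scatter); both exchange an open-chain amine for a ring amine, and the ring amine gave the lowest number. Going by the values given here, no measured step exchanges one ring amine for another, which is the change from compound 3 to compound 4. Compound 4 keeps a ring amine directly on the piperazine nitrogen. The number for compound 4 is expected to stay near that of compound 3, with a step of a 2.5-fold higher number from compound 3 to compound 4 (0.40 log units; beyond the scatter) that is not expected to exceed the scatter by much. Compound 4 is estimated at 2 nM in this assay, within a range of 0.4 nM to 10 nM.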

Compound 4, inhibition constant: 5.6 nM
Compound 4: the middle estimate sits 2.8-fold (0.45 log units) below what was measured; measured number inside the range.
By their numbers in this assay, from the lowest: compound 3; then compounds 4 and 1 (each within the scatter of the next); then compound 2.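

In this assay, the exchange of one ring amine for another is no longer neutral: there is a 7.0-fold higher number from compound 3 to compound 4 (0.85 log units; beyond the scatter), so this position on the piperazine nitrogen distinguishes between two ring amines, and the 1-cyclopropylpiperidin-4-yl group remains the best of the groups shown here. The earlier suggestion that a ring amine outperforms an open-chain amine therefore holds only in part, as the data show a 19-fold lower number from compound 2 to compound 4 (1.28 log units; beyond the scatter) but only a 1.8-fold lower number from compound 1 to compound 4 (0.25 log units; within the scatter), which leaves compound 4 and compound 1 indistinguishable and makes compound 1 the exception to that pattern. A ring amine on this nitrogen is thus not enough in itself to reach the number of compound 3. No measurement shown here explains why the two ring amines differ.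

Going by these compounds, it remains open whether the opposite configuration at the defined stereocentre of the bicyclic group would shift the number in either direction. On these data alone, it also remains open whether the cyclopropyl group on the piperidine nitrogen matters, as a 1-methylpiperidin-4-yl or 1-isopropylpiperidin-4-yl group in its place would show.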